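Swapping Methoxy Groups for Chlorine and Trifluoromethyl on the Benzylamine

This account rests on a few compounds, and the source may have more. Where it says the series, first, only, none or still open, it means among the compounds named here.

Among the measured compounds shown here, compound 2 `COc1ccc(CNCCCNS(=O)(=O)c2cc(C(F)(F)F)cc(C(F)(F)F)c2)cc1OC` gives the highest number of the two compounds measured so far: in a functional assay on PANC-1 cells (Homo sapiens) for inhibition, read by MTT assay, with a stated time of 72 h (on this read-out higher numbers stand for weaker inhibition of growth and lower numbers for stronger inhibition of growth), compound 2 gives 18000 nM, while compound 1 `O=S(=O)(NCCCNCc1ccc(Cl)c(Cl)c1)c1cc(C(F)(F)F)cc(C(F)(F)F)c1` gives 5600 nM. For the measured compounds named here, the only change between them is the 3,4-dimethoxyphenyl of compound 2 in place of the 3,4-dichlorophenyl of compound 1, and that step went a 3.2-fold higher number from compound 1 to compound 2 (0.51 log units; beyond the scatter). Compound 3 `O=S(=O)(NCCCNCc1ccc(Cl)c(C(F)(F)F)c1)c1cc(C(F)(F)F)cc(C(F)(F)F)c1` carries 4-chloro-3-(trifluoromethyl)phenyl in place of 3,4-dimethoxyphenyl on a saturated chain carbon bound to an amine nitrogen. Going by the values given here, the incoming group, like that of compound 1, bears chlorine and no hydrogen-bond acceptors, so the one step that bears on it is a 3.2-fold higher number from compound 1 to compound 2 (0.51 log units; beyond the scatter) read in reverse. A step of similar size in the opposite direction is expected, a 3.3-fold lower number from compound 2 to compound 3 (0.51 log units; beyond the scatter). That would put compound 3 near compound 1. In this assay compound 3 is therefore estimated at 5500 nM, with a range from 2000 nM to 15000 nM.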

Compound 3, concentration for 50% growth inhibition: 10000 nM
The estimate for compound 3 lay 1.8-fold (0.26 log units) below the measured number; low and high end bracket the measured number.
By their numbers in this assay, from the lowest: compounds 1, 3 and 2 (each within the scatter of the next, the first and the last beyond it).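

Putting 4-chloro-3-(trifluoromethyl)phenyl in place of 3,4-dimethoxyphenyl gives a 1.8-fold lower number from compound 2 to compound 3 (0.26 log units; within the scatter), and trifluoromethyl in place of chloro on an aromatic carbon gives a 1.8-fold higher number from compound 1 to compound 3 (0.25 log units; within the scatter). In this assay, compound 3 therefore cannot be told apart from either of the other two, even though those two differ from each other beyond the scatter, so this position has now given one clear difference and two steps too small to interpret. No measured property of these groups is available to account for these numbers.

The compounds shown leave open how a plain phenyl, with neither chloro nor methoxy, or a phenyl carrying a single nitrile would compare at this position. They also leave open whether a longer chain would change how much these ring groups matter.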